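The source may report more compounds than this note shows. Statements on the series, on what has been measured and on what is new or still open speak of the compounds shown alone.

In a functional assay on Jurkat cells (Homo sapiens) for cytotoxicity, with a stated time of 72 h (a higher number here means that more compound is needed for the effect, a lower number that less compound is needed), compound 1 `C=C[C@@](C)(/C=C/c1ccc(O)c(CO)c1)CCC=C(C)C` gives > 49000 nM as a limit only. Compound 2 `C=C[C@@](C)(/C=C/c1ccc(O)c(/C=C(\C)C(=O)OCC)c1)CCC=C(C)C` also gives only a limit, with > 49000 nM as its reading, so its place on the scale is bounded on one side alone. The two compounds share the limit of > 49000 nM in this assay, at which 2 of the 2 values shown sit, and no numerical value has been seen yet. Going by the values given here, the one measured step is a step that the two limits leave unreadable from compound 1 to compound 2 and it concerns an aromatic carbon, not the chain carbon changed next, so it offers no size to carry over. Compound 3 `CCOC(=O)/C(C)=C/c1cc(/C=C/[C@](C)(/C=C/c2ccc(OC)cc2)CCC=C(C)C)ccc1O` brings the change 2-(4-methoxyphenyl)ethenyl in place of vinyl on a saturated chain carbon bound to a double-bonded chain carbon and two saturated chain carbons to that chain. The step expected in this assay is an at least 1.4-fold lower number from compound 2 to compound 3 (0.14 log units; that floor lies within the scatter) in the direction of less compound needed, and another limit reading remains quite possible. Compound 3 is estimated at 35000 nM with an expected range from 10000 nM to 70000 nM for its value.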

Compound 3, half-maximal effective concentration: > 49000 nM
Compound 3 was reported as a limit; the forecaster's own chance of this, stated with the estimate: 55%; middle value at least 1.4-fold (0.14 log units) away from the limit.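

Compound 2 and compound 3 are both limit readings in this assay, so no step can be read between them, and both sit at the same limit: the limit of > 49000 nM in this assay, at which 3 of the 3 values shown sit.

The compounds shown leave open where any of the three lies on the scale, and which change to the shared core would give a numerical value.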